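From a chlorobenzyl to a cyanobenzyl group

The source may hold more compounds than are shown below. What is called first, only, known or untested is meant among the compounds shown, and "the series" means these compounds.

Measured values in a functional assay on Raji cells (Homo sapiens) for antiproliferative activity, read by MTT assay, with a stated time of 72 h (a lower number here means a stronger inhibitor, a higher number a weaker inhibitor), so far:
Compound 1 `CN(Cc1nc(C2CCN(Cc3ccccc3)CC2)no1)c1ncc(C(=O)NO)cn1` gives 27.6 nM
Compound 2 `CN(Cc1nc(C2CCN(Cc3ccccc3F)CC2)no1)c1ncc(C(=O)NO)cn1` gives 98.6 nM
Compound 3 `CN(Cc1nc(C2CCN(Cc3ccccc3Cl)CC2)no1)c1ncc(C(=O)NO)cn1` gives 48.3 nM

Compound 3 has the second highest of the three numbers (48.3 nM). Its two measured steps place it less sharply than that rank suggests (a 1.8-fold higher number from compound 1 to compound 3 (0.24 log units; within the scatter); a 2.0-fold lower number from compound 2 to compound 3 (0.31 log units; beyond the scatter)).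

Compound 4 `CN(Cc1nc(C2CCN(Cc3ccc(C#N)cc3)CC2)no1)c1ncc(C(=O)NO)cn1` has not yet been measured. It carries 4-cyanophenyl in place of 2-chlorophenyl on a saturated chain carbon bound to an amine nitrogen in a ring. For the measured compounds named here, no measured compound holds a nitrile, so the nearest evidence is the pair of steps that put a halogen on an aromatic carbon. Fluoro gave one (a 3.6-fold higher number from compound 1 to compound 2 (0.55 log units; beyond the scatter)) and chloro the other (a 1.8-fold higher number from compound 1 to compound 3 (0.24 log units; within the scatter)). These steps are small, and they cannot show which way a nitrile would move the number. On these data alone, no step beyond the scatter is therefore expected in this assay, and the direction stays open. The expected change is slight (a 1.0-fold higher number from compound 3 to compound 4 (0.02 log units; within the scatter)). For compound 4 the expected value is 50 nM with an estimated range from 20 nM to 130 nM as the likely span.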

Compound 4, half-maximal inhibitory concentration: 117 nM
Estimate against measurement, compound 4: 2.3-fold (0.37 log units) below; the range from low to high includes it.
By their numbers in this assay, from the lowest: compounds 1 and 3 (each within the scatter of the next); then compounds 2 and 4 (each within the scatter of the next).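

On the phenyl ring of this benzyl group, a nitrile behaves in this assay like the fluoro of compound 2 rather than the chloro of compound 3: compound 4 sits well above the unsubstituted parent (a 4.2-fold higher number from compound 1 to compound 4 (0.63 log units; beyond the scatter)), and it cannot be told apart from the fluoro compound (a 1.2-fold higher number from compound 2 to compound 4 (0.07 log units; within the scatter)). The swap of 2-chlorophenyl for 4-cyanophenyl is therefore not neutral (a 2.4-fold higher number from compound 3 to compound 4 (0.38 log units; beyond the scatter)), and among the compounds shown, a substituent on this ring gives a number beyond the scatter above compound 1 in compounds 2 and 4, with compound 3 the exception. Nothing shown gives a measured reason for these shifts, so the result stands as a description only.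

The step from compound 3 to compound 4 changes both the group and its place on the ring, and only a 4-chlorophenyl or a 2-cyanophenyl compound could separate the two. On these data alone, it also stays open whether any substituent here can match the plain benzyl group of compound 1 beyond the chloro case, for instance a methoxy, a methyl or an amine on the same ring.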